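Inverting a single stereocentre in a kinase-type antiproliferative series

This account rests on a few compounds, and the source may have more. Where it says the series, first, only, none or still open, it means among the compounds named here.

Within the data shown here, compound 2, with structure `CN1CCN(c2ccc(Nc3ncc4nc(Nc5ccc(F)cc5)n([C@H]5CCNC5)c4n3)cc2)CC1`, is the weakest of the three compounds measured so far in a functional assay on HCC827 cells (Homo sapiens) for antiproliferative activity, read by MTT assay, with a stated time of 72 h; a higher number here means a weaker inhibitor, a lower number a stronger inhibitor: compound 2 gives 1220 nM. Its nearest neighbour is compound 1, `CN1CCN(c2ccc(Nc3ncc4nc(Nc5ccccc5)n([C@H]5CCNC5)c4n3)cc2)CC1`, which in this assay gives 530 nM, the step being a 2.3-fold higher number from compound 1 to compound 2 (0.36 log units; beyond the scatter). Far below both stands compound 3, `CN1CCN(c2ccc(Nc3ncc4nc(Nc5ccccc5)n([C@H]5CCN(S(=O)(=O)C6CC6)C5)c4n3)cc2)CC1`, which gives 1.6 nM in this assay, reached from compound 1 by a 330-fold lower number from compound 1 to compound 3 (2.52 log units; beyond the scatter).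

Compound 4 has structure `CN1CCN(c2ccc(Nc3ncc4nc(Nc5ccc(F)cc5)n([C@@H]5CCNC5)c4n3)cc2)CC1`. It differs from compound 2 as follows: the two compounds have the same atoms and bonds and differ only in configuration as drawn: 1 of 1 stereo elements differ; a stereocentre at a saturated ring carbon is drawn S in compound 2 and R in compound 4. Neither measured step bears on this change: the fluoro step and the sulfonyl step each alter atoms, while here nothing leaves and nothing enters. Among the measured compounds shown here, no pair of compounds differing only in configuration has been measured, so the direction of the step is not anchored in the data. The account therefore treats the outcome as open, allowing a wide span on either side of compound 2, with the expected step being a 2.0-fold higher number from compound 2 to compound 4 (0.31 log units; beyond the scatter). Compound 4 is estimated to give 2500 nM in this assay, within a range of 600 nM to 12000 nM.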

Compound 4, half-maximal inhibitory concentration: 300 nM
Compound 4: middle estimate off by 8.3-fold (0.92 log units), on the high side, outside the stated range (below it).
By their numbers in this assay, from the lowest: compound 3; then compounds 4 and 1 (each within the scatter of the next); then compound 2.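

In this assay, inverting the stereocentre gives a 4.1-fold lower number from compound 2 to compound 4 (0.61 log units; beyond the scatter), so the configuration at this saturated ring carbon affects the read-out, which neither the fluoro step nor the sulfonyl step could show. The step can be assigned to that stereocentre alone, because nothing else separates the pair: the fact that compounds 2 and 4 differ only in the configuration as drawn. It is still modest beside a 330-fold lower number from compound 1 to compound 3 (2.52 log units; beyond the scatter), so among the changes shown, the inversion does far less than placing cyclopropylsulfonyl on the amine nitrogen in the ring.

On these data alone, it remains open whether the inversion would give a step of the same direction and size in compound 1 or in compound 3, which lack the fluoro group. As far as these compounds go, it is also open what an acetyl or methylsulfonyl group on that nitrogen would give in either configuration.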